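The compounds below may be only part of what the source reports. "The series", "measured", "known", "first", "only" and "open" are said of these compounds alone.

Measured in a functional assay (aorta) for antagonist activity, with Oryctolagus cuniculus as the target; on this read-out higher numbers stand for weaker inhibition and lower numbers for stronger inhibition:
Compound 1 `CCCCc1ccc(CNC(=O)OC(C)(C)C)c(=O)n1Cc1ccc(-c2ccccc2-c2nn[nH]n2)cc1` gives 10 nM.
Compound 2 `CCCCc1ccc(CN)c(=O)n1Cc1ccc(-c2ccccc2-c2nn[nH]n2)cc1` gives 20 nM.
Compound 3 `CCCCc1ccc(CNC(C)=O)c(=O)n1Cc1ccc(-c2ccccc2-c2nn[nH]n2)cc1` gives 3 nM.

Compound 1 stands second highest of the three: its number lies within the scatter of compound 2, as a 2.0-fold higher number from compound 1 to compound 2 (0.30 log units; within the scatter) shows, while compound 3 sits beyond it, as a 3.3-fold lower number from compound 1 to compound 3 (0.52 log units; beyond the scatter) shows. Compound 4 `CCCCc1ccc(CNS(=O)(=O)c2ccccc2)c(=O)n1Cc1ccc(-c2ccccc2-c2nn[nH]n2)cc1` differs from compound 1 in one place: phenylsulfonyl in place of tert-butoxycarbonyl on an amine nitrogen. Going by the values given here, the steps that bear on this change both alter the same amine nitrogen, a 3.3-fold lower number from compound 1 to compound 3 (0.52 log units; beyond the scatter) and a 6.7-fold lower number from compound 2 to compound 3 (0.82 log units; beyond the scatter), and both were modest. Among the compounds with values here, no measured step brings in a sulfur atom or an aromatic ring, so the direction is uncertain. On this basis, no step beyond the scatter is expected, no change at the digits printed from compound 1 to compound 4 (within the scatter). Compound 4 is therefore estimated at 10 nM, in the range 3 nM to 40 nM.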

Compound 4, half-maximal inhibitory concentration: 7 nM
Compound 4: middle estimate off by 1.4-fold (0.15 log units), on the high side, within the range that was stated.
By their numbers in this assay, from the lowest: compound 3; then compounds 4, 1 and 2 (each within the scatter of the next, the first and the last beyond it).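

Going by these compounds alone, a sulfur atom and an aromatic ring, neither present in the earlier compounds, are accepted on this amine nitrogen: phenylsulfonyl and tert-butoxycarbonyl cannot be told apart (a 1.4-fold lower number from compound 1 to compound 4 (0.15 log units; within the scatter)). Phenylsulfonyl still does not reach acetyl (a 2.3-fold higher number from compound 3 to compound 4 (0.37 log units; beyond the scatter)), yet it clearly betters the free amine (a 2.9-fold lower number from compound 2 to compound 4 (0.46 log units; beyond the scatter)). No measurement shown here accounts for these differences. Open, as far as these compounds go, is whether methylsulfonyl, benzoyl or a urea on this nitrogen would match acetyl, and whether a chlorine or methoxy group on the phenyl ring would shift the number.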